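Capping the Aromatic Nitrogen of Compound 2

A few compounds are considered here, and "the series" means these few. Any claim that something is new, unique, unknown or untested is made for them only; others in the source may bear on it.

Compound 1 `COc1cc(/C=C/C(=O)c2cccc(NC(=O)c3cccs3)c2)ccc1O` gives 80% in a functional assay on HUVEC cells (Homo sapiens) for inhibition, tested at 5 ug/mL; a lower number here means a weaker effect, a higher number a stronger effect of the compound at the concentration tested.
Compound 2 `COc1cc(/C=C/C(=O)c2cccc(N)c2)ccc1O` gives 50% in this assay.

For the measured compounds named here, compound 2 stands lowest of the two numbers in this assay, with compound 1 as its only neighbour. Going by the values given here, the single measured step, a number 30 percentage points lower from compound 1 to compound 2 (beyond the scatter), accompanies the loss of an acyl group from the nitrogen. Compound 3 `CCCC(=O)Nc1cccc(C(=O)/C=C/c2ccc(O)c(OC)c2)c1` differs from compound 2 by propylcarbonyl in place of hydrogen on a nitrogen on an aromatic ring. Among the compounds with values here, since this change returns an acyl group to the same nitrogen, the step in this assay is expected to run in the opposite direction and to be modest, though with only one comparable step its size is uncertain. Compound 3 is therefore estimated at 70%, within 55% to 85%, an expected step of a number 20 percentage points higher from compound 2 to compound 3 (beyond the scatter).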

Compound 3, a percentage reported as inhibition, at one concentration (the size of the read-out at that concentration, not a potency): 57%
Estimate against measurement, compound 3: 13 percentage points above; the range from low to high includes it.
By their numbers in this assay, from the lowest: compounds 2 and 3 (each within the scatter of the next); then compound 1.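

In this assay an acyl group on this nitrogen does not by itself raise the number: propylcarbonyl in place of hydrogen gives a number 7 percentage points higher from compound 2 to compound 3 (within the scatter), while propyl in place of thiophen-2-yl on the carbonyl carbon gives a number 23 percentage points lower from compound 1 to compound 3 (beyond the scatter). The larger step seen earlier therefore depends on what the carbonyl carries, not only on the nitrogen being capped. Nothing available accounts for this difference.

The compounds shown leave open whether phenyl or furan-2-yl on the carbonyl would match thiophen-2-yl. They also leave open whether a chain longer than propyl would differ from propyl.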